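The source may report more compounds than this note shows. Statements on the series, on what has been measured and on what is new or still open speak of the compounds shown alone.

Compound 2 `Cc1ccc(-c2nn(-c3ccccc3)cc2C(=O)NC(=S)Nc2ccc(Cl)cc2)cc1` gives the highest of the two numbers in a functional assay on NCI-H460 cells (Homo sapiens) for inhibition, read by CCK-8 assay, with a stated time of 48 h (on this read-out lower numbers stand for stronger inhibition and higher numbers for weaker inhibition), at 3650 nM. Compound 1 `Cc1ccc(NC(=S)NC(=O)c2cn(-c3ccccc3)nc2-c2ccc(Cl)cc2)cc1` gives 3120 nM in this assay, which lies within the scatter of compound 2; the two values show no separation. Compound 3 `O=C(NC(=S)Nc1ccc(Cl)cc1)c1cn(-c2ccccc2)nc1-c1ccc(Cl)cc1` carries chloro in place of methyl on an aromatic carbon. For the measured compounds named here, no step between measured compounds covers this change, and the two values known give no direction for it. No step beyond the scatter is expected in this assay. Compound 3 is therefore estimated at 3200 nM, with a range of 1400 nM to 7500 nM. The expected step is a 1.1-fold lower number from compound 2 to compound 3 (0.06 log units; within the scatter).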

Compound 3, half-maximal inhibitory concentration: 3260 nM
Compound 3: the middle estimate sits 1.0-fold (0.01 log units) below what was measured, and the stated range covers the measured number.
By their numbers in this assay, from the lowest: compounds 1, 3 and 2 (each within the scatter of the next).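

In this assay the change from 4-methylphenyl to 4-chlorophenyl separates nothing at either of the two places where a methyl stood: the steps are a 1.1-fold lower number from compound 2 to compound 3 (0.05 log units; within the scatter) and a 1.0-fold higher number from compound 1 to compound 3 (0.02 log units; within the scatter) and both lie within the scatter. Compound 3, with chloro at both places, shows that methyl and chloro are not told apart at either place. No measurement at hand offers any reason for this.

Open, going by these compounds, is whether another kind of group on these aromatic carbons, such as an amine or a carboxylic acid, would give a step beyond the scatter. The compounds shown carry only methyl and chloro there.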